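Swapping acetyl for dimethylamino on a pyrazole cytotoxic series

The source may hold more compounds than are shown below. What is called first, only, known or untested is meant among the compounds shown, and "the series" means these compounds.

Measured compounds:
- compound 1 `COc1cc(C)cc(-c2c(-c3ccnc(-c4ccc(C(C)=O)cc4)c3)cnn2CC#N)c1`: -14%
- compound 2 `Cc1cc(O)cc(-c2nn(CC#N)cc2-c2ccnc(-c3ccc(Oc4ccccc4)cc3)c2)c1`: 2%

In a functional assay on NCI-H522 cells (Homo sapiens) for cytotoxicity, read by sulforhodamine B assay, with a stated time of 48 h, tested at 1 uM (on this read-out lower numbers stand for a stronger effect and higher numbers for a weaker effect at the one concentration tested), compound 1 gives -14%, the lowest of the two numbers shown. Compound 2 gives 2% in this assay, a gap beyond the usual scatter; compound 2 also differs from compound 1 in more than one place, so no single change can be read from this pair.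

Compound 3 `COc1cc(C)cc(-c2c(-c3ccnc(-c4ccc(N(C)C)cc4)c3)cnn2CC#N)c1` differs from compound 1 in one place: dimethylamino in place of acetyl on an aromatic carbon. Among the measured compounds shown here, no single-change step between measured compounds is available to guide the expectation, so the step of a number 6 percentage points higher from compound 1 to compound 3 (within the scatter) is expected to stay within the scatter. Compound 3 is therefore estimated at -8%, in the range -35% to 20%.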

Compound 3, a percentage reported as activity, at one concentration (the size of the read-out at that concentration, not a potency): -53%
Beside the measured number, compound 3's estimate is 45 percentage points above it; the measured number lies below the stated range.
By their numbers in this assay, from the lowest: compound 3; then compound 1; then compound 2.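

In this assay the change from 4-acetylphenyl to 4-(dimethylamino)phenyl gives a number 39 percentage points lower from compound 1 to compound 3 (beyond the scatter) and so shows that this position strongly affects the read-out. The two groups have the same count of heavy atoms and of hydrogen-bond acceptors, so these counts alone do not predict the outcome. Nothing measured here explains the step. This single step cannot show whether the dimethylamino group itself matters or only the loss of acetyl. A primary amine or a carboxylic acid at the same place could help separate the two, and the step may not carry over to other substituents on the shared core.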